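A few compounds are considered here, and "the series" means these few. Any claim that something is new, unique, unknown or untested is made for them only; others in the source may bear on it.

Compound 2 `CC(C)n1cnc2c(Nc3cccc(Cl)c3)nc(NCOCc3ccc(C(=O)Nc4ccccc4N)cc3)nc21` gives 7.12% in a functional assay on HCT-116 cells (Homo sapiens) for antiproliferative activity, read by CCK-8 assay, with a stated time of 72 h, tested at 2 uM; a higher number here means a stronger effect of the compound at the concentration tested, a lower number a weaker effect. On the numbers shown it sits within the scatter of compound 1 `CC(C)n1cnc2c(Nc3ccccc3)nc(NCOCc3ccc(C(=O)Nc4ccccc4N)cc3)nc21`, which gives 6.85%, the step of a number 0.3 percentage points higher from compound 1 to compound 2 (within the scatter) being within the scatter, and below compound 3 `CC(C)n1cnc2c(Nc3cccc(Cl)c3)nc(NCOCc3ccc(/C=C/C(=O)Nc4ccccc4N)cc3)nc21`, which gives 18.5% after the step of a number 11.4 percentage points higher from compound 2 to compound 3 (beyond the scatter). Compound 4 `Nc1ccccc1NC(=O)c1ccc(COCNc2nc(Nc3cccc(Cl)c3)c3ncn(C4CCCC4)c3n2)cc1` differs from compound 2 by cyclopentyl in place of isopropyl on an aromatic nitrogen. Neither measured step touches the group on that aromatic nitrogen; one concerns a chloro substituent and the other the amide-bearing arm, so nothing measured bears on this change. Without such a step, the estimated step of a number 0.9 percentage points higher from compound 2 to compound 4 (within the scatter) in this assay is expected to be none beyond the scatter. Compound 4 is therefore expected to give 8%, in the range 0% to 22%.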

Compound 4, a percentage reported as inhibition, at one concentration (the size of the read-out at that concentration, not a potency): 29.2%
Compound 4: the middle estimate sits 21.2 percentage points below what was measured; measured number outside the range, above it.
By their numbers in this assay, from the lowest: compounds 1 and 2 (each within the scatter of the next); then compound 3; then compound 4.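

Among the compounds shown here, the group on the aromatic nitrogen, untouched by the earlier steps, turns out to matter in this assay: replacing isopropyl with cyclopentyl gives a number 22.1 percentage points higher from compound 2 to compound 4 (beyond the scatter). The earlier compounds had shown only that the chloro substituent and the amide-bearing arm could be varied, so this is the first sign that the read-out responds to this position as well. Nothing available explains the gain. The compounds shown leave open whether cyclobutyl, cyclohexyl or a ring carrying an amine would go further at this nitrogen. They also leave open how cyclopentyl behaves alongside the ethenyl arm of compound 3.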